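Halogenated Phenyl Variants on a Shared Core

The compounds below may be only part of what the source reports. "The series", "measured", "known", "first", "only" and "open" are said of these compounds alone.

Measured compounds:
compound 1, `O=c1oc2ccccc2c2nc3c(ccc4cc[nH]c43)c(-c3cccc(Br)c3)c12`: 70700 nM
compound 2, `O=c1oc2ccccc2c2nc3c(ccc4cc[nH]c43)c(-c3c(Cl)cccc3Cl)c12`: 70700 nM
compound 3, `O=c1oc2ccccc2c2nc3c(ccc4cc[nH]c43)c(-c3ccc(F)cc3)c12`: 70700 nM

In a functional assay on B16-F10 cells (Mus musculus) for cytotoxicity (on this read-out higher numbers stand for weaker inhibition and lower numbers for stronger inhibition), compound 1 gives 70700 nM. Compound 2 gives 70700 nM in this assay, and compound 3 gives 70700 nM. Compound 1 therefore stands level with compounds 2 and 3; its nearest neighbour is compound 2 and its furthest is compound 3, yet both gaps lie within the scatter. The three steps, no change at the digits printed from compound 1 to compound 2 (within the scatter), no change at the digits printed from compound 1 to compound 3 (within the scatter) and no change at the digits printed from compound 2 to compound 3 (within the scatter), all show that exchanging one halogenated phenyl for another on the shared core leaves the read-out where it was.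

Compound 4, `O=c1oc2ccccc2c2nc3c(ccc4cc[nH]c43)c(-c3cccc(Cl)c3Cl)c12`, has not yet been measured. Its difference from compound 1 is 2,3-dichlorophenyl in place of 3-bromophenyl on an aromatic carbon. The steps from compound 1 to compound 2 and from compound 1 to compound 3 bear on this change most directly, and both were flat. Compound 4 is therefore expected to show a step of no change at the digits printed from compound 1 to compound 4 (within the scatter), that is, none beyond the scatter. The estimate for compound 4 is 70700 nM, within a range from 35000 nM to 141000 nM.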

Compound 4, half-maximal inhibitory concentration: 70700 nM
Compound 4: the middle estimate sits on the measured number at the digits printed; the measured number falls inside the stated range.
By their numbers in this assay, from the lowest: compounds 1, 2, 3 and 4 (each within the scatter of the next).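

In this assay, the 2,3-dichlorophenyl group brings a fourth halogenated phenyl to this aromatic carbon, and the read-out shows no change at the digits printed from compound 1 to compound 4 (within the scatter) together with no change at the digits printed from compound 3 to compound 4 (within the scatter) and no change at the digits printed from compound 2 to compound 4 (within the scatter) on the shared core. The result extends the flat picture to two further changes: two chlorine atoms in place of the single bromine of 3-bromophenyl, and the 2,3-dichlorophenyl pattern in place of the 2,6-dichlorophenyl pattern. No supporting data are available to account for this flat read-out.

The compounds shown leave open whether a phenyl group carrying an amine or a carboxylic acid, or a longer alkyl chain on this aromatic carbon, would move the read-out away from the number shared by these four compounds. They also leave open whether a halogen-free phenyl would give that same number.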